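A few compounds are considered here, and "the series" means these few. Any claim that something is new, unique, unknown or untested is made for them only; others in the source may bear on it.

Working notes on the series.

Of the compounds shown here, three sharing one core have been measured. Compound 1 `O=C(CSc1nnc(-c2ccncc2)n1-c1ccccc1)N/N=C/c1ccccc1` gives 18600 nM in a functional assay on HepG2 cells (Homo sapiens) for inhibition, read by MTT assay, with a stated time of 48 h; on this read-out lower numbers stand for stronger inhibition and higher numbers for weaker inhibition. Compound 2 `O=C(CSc1nnc(-c2ccncc2)n1-c1ccccc1)N/N=C/c1ccc([N+](=O)[O-])cc1` gives 15900 nM in this assay; the step of a 1.2-fold lower number from compound 1 to compound 2 (0.07 log units; within the scatter) stays within the scatter, so the two numbers are not separated. Compound 3 `O=C(CSc1nnc(-c2ccncc2)n1-c1ccccc1)N/N=C/c1ccc(Br)cc1` gives 5990 nM in this assay and stands lowest of the three numbers: the steps of a 3.1-fold lower number from compound 1 to compound 3 (0.49 log units; beyond the scatter) and a 2.7-fold lower number from compound 2 to compound 3 (0.42 log units; beyond the scatter) are both beyond the scatter, so compound 3 is the most potent of the measured set.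

Compound 4 `O=C(CSc1nnc(-c2ccncc2)n1-c1ccccc1)N/N=C/c1ccc(Cl)cc1` has not been measured. Against compound 3 its change is chloro in place of bromo on an aromatic carbon. For the measured compounds named here, no measured step exchanges one halogen for another. Going by the values given here, the steps that bear on the same ring carbon, a 3.1-fold lower number from compound 1 to compound 3 (0.49 log units; beyond the scatter) and a 2.7-fold lower number from compound 2 to compound 3 (0.42 log units; beyond the scatter), show only that bromo there gives a lower number than hydrogen or nitro; they do not say how chloro compares with bromo. With nothing to separate the two halogens, the step is expected to be small: a 1.3-fold higher number from compound 3 to compound 4 (0.10 log units; within the scatter) is estimated to stay within the scatter, with a lean toward a slightly higher number rather than a lower one. Compound 4 is therefore expected to give 7500 nM in this assay, estimated to fall between 3000 nM and 19000 nM.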

Compound 4, half-maximal inhibitory concentration: 11000 nM
Compound 4: the middle estimate sits 1.5-fold (0.17 log units) below what was measured; measured number inside the range.
By their numbers in this assay, from the lowest: compounds 3, 4, 2 and 1 (each within the scatter of the next, the first and the last beyond it).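

In this assay, for the compounds shown here, the exchange of bromo for chloro gives the first halogen-for-halogen step at this ring carbon, and that step (a 1.8-fold higher number from compound 3 to compound 4 (0.26 log units; within the scatter)) does not separate the two halogens. Chloro is equally unseparated from hydrogen (a 1.7-fold lower number from compound 1 to compound 4 (0.23 log units; within the scatter)) and from nitro (a 1.4-fold lower number from compound 2 to compound 4 (0.16 log units; within the scatter)), so compound 4 lies within the scatter of all three other compounds, while compound 3 remains apart from compound 1 and compound 2 only. The lower number seen with bromo therefore cannot be said to extend to chloro, compound 3 can no longer be set apart from every compound in the set, and no information is available to account for this result.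

The compounds shown leave open how fluoro, iodo, a methoxy group or an amine would read on this carbon, and whether bromo and chloro would separate at all on repeated measurement. They also leave open whether the 4-bromophenyl to 4-chlorophenyl change would read the same way with the shared core altered elsewhere.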